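Lengthening the alkyne side chain by one carbon

The source may hold more compounds than are shown below. What is called first, only, known or untested is meant among the compounds shown, and "the series" means these compounds.

Measured so far in a functional assay on HL-60 cells (Homo sapiens) for inhibition, read by MTT assay, with a stated time of 72 h; a lower number here means a stronger inhibitor, a higher number a weaker inhibitor
- compound 1 `CCCO[C@@H]1C=CC(=O)[C@@H](CO)O1` gives 10700 nM
- compound 2 `O=C1C=C[C@@H](OC2CCCC2)O[C@@H]1CO` gives 4200 nM
- compound 3 `C#CCO[C@@H]1C=CC(=O)[C@@H](CO)O1` gives 9300 nM

Among these three numbers compound 3 stands second highest. The unmeasured compound 4 `C#CCCO[C@@H]1C=CC(=O)[C@@H](CO)O1` differs from it by propargyl in place of ethynyl on a saturated chain carbon bound to an oxygen on a saturated carbon and this change reads propargyl in place of ethynyl on a saturated chain carbon bound to an oxygen on a saturated carbon. Within the data shown here, the closest precedent is the swap of ethyl for ethynyl, a 1.2-fold lower number from compound 1 to compound 3 (0.06 log units; within the scatter) and it stayed small. The larger steps of a 2.5-fold lower number from compound 1 to compound 2 (0.41 log units; beyond the scatter) and a 2.2-fold higher number from compound 2 to compound 3 (0.35 log units; beyond the scatter) both involve cyclopentyl, and no ring enters here. In this assay the estimated step is therefore a 1.2-fold lower number from compound 3 to compound 4 (0.07 log units; within the scatter) and no move beyond the scatter is expected. For compound 4 the estimate is 8000 nM with an expected range of 4000 nM to 15000 nM around it.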

Compound 4, half-maximal inhibitory concentration: 2500 nM
For compound 4 the middle estimate is 3.2-fold (0.51 log units) above the measured one, and the stated range ends above it.
By their numbers in this assay, from the lowest: compounds 4 and 2 (each within the scatter of the next); then compounds 3 and 1 (each within the scatter of the next).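

In this assay the step of a 1.2-fold lower number from compound 1 to compound 3 (0.06 log units; within the scatter) suggested that an alkyne at the chain end changes little, yet its distance along the chain matters, with a 3.7-fold lower number from compound 3 to compound 4 (0.57 log units; beyond the scatter) for one added carbon. The but-3-yn-1-yl chain also improves on propyl, with a 4.3-fold lower number from compound 1 to compound 4 (0.63 log units; beyond the scatter) as the step between them. An open chain can thus reach the level of the cyclopentyl group, with a 1.7-fold lower number from compound 2 to compound 4 (0.23 log units; within the scatter) and no separation between the two.

Nothing available explains this effect of chain length. From the compounds shown here alone, whether a longer alkyne chain or an amine at the chain end would keep this level remains open.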